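Removing the pyridine methyl in two thiosemicarbazide amidrazones

The compounds below may be only part of what the source reports. "The series", "measured", "known", "first", "only" and "open" are said of these compounds alone.

Measured compounds:
compound 1 `Cc1ccnc(/C(N)=N/NC(=S)N2CCN(c3ccccn3)CC2)c1`: 74.8%
compound 2 `N/C(=N\NC(=S)N1CCCCC1)c1ccccn1`: 86.5%
compound 3 `Cc1cccc(/C(N)=N/NC(=S)N2CCCCC2)n1`: 63.2%

Three compounds were measured in a functional assay on A-375 cells (Homo sapiens) for cytotoxicity, read by MTT assay, with a stated time of 72 h, tested at 3 uM; a lower number here means less inhibition of growth, a higher number more inhibition of growth at the concentration tested. Compound 2 gives 86.5%, compound 3 gives 63.2%, and compound 1 gives 74.8%. Compound 4 `N/C(=N\NC(=S)N1CCN(c2ccccn2)CC1)c1ccccn1` is not yet measured. It differs from compound 1 by hydrogen in place of methyl on an aromatic carbon. The same kind of change separates compound 3 from compound 2, (hydrogen in place of methyl on an aromatic carbon); there the hydrogen enters next to the ring nitrogen, whereas in compound 4 it enters opposite the ring nitrogen. That step gave a number 23.3 percentage points higher from compound 3 to compound 2 (beyond the scatter). How the core of compound 1 differs from that of compound 3 is not broken down here. Compound 4 is expected to gain because a number 23.3 percentage points higher from compound 3 to compound 2 (beyond the scatter) points upward. Since the place is not the same, a somewhat smaller step is expected: a number 10.2 percentage points higher from compound 1 to compound 4 (beyond the scatter). Compound 4 is estimated at 85%, between 70% and 96%.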

Compound 4, percent growth inhibition at one concentration: 73.7%
Compound 4: the middle estimate sits 11.3 percentage points above what was measured; measured number inside the range.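

In this assay, removing the methyl gave a number 1.1 percentage points lower from compound 1 to compound 4 (within the scatter), so the rise seen on the other core did not reappear on this one. The change therefore cannot be carried from one core to the other as a fixed step: the same change on two cores in this assay, a number 23.3 percentage points higher (beyond the scatter) from compound 3 to compound 2 and a number 1.1 percentage points lower (within the scatter) from compound 1 to compound 4, 24.4 percentage points apart, beyond the scatter of two such steps This does not show why the two steps differ, as the cores are not the same and the methyl stands in a different place on the ring in each pair, so the two influences cannot be separated.

The compounds shown leave open what a methyl opposite the ring nitrogen would do on the core of compound 2. They also leave open whether an amine or a methoxy group at that ring carbon would change the number on either core.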